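An isopropyl swap on compound 2

The source may hold more compounds than are shown below. What is called first, only, known or untested is meant among the compounds shown, and "the series" means these compounds.

Values so far in a functional assay, read by spectrophotometry, tested at 100 uM; a higher number here means a weaker inhibitor, a lower number a stronger inhibitor:
Compound 1 `O=C(/C=C/c1ccc(Cl)cc1)c1cccc(NC(=O)c2cc(-c3ccncc3)n[nH]2)c1` gives 78900 nM
Compound 2 `CN(C)c1ccc(/C=C/C(=O)c2cccc(NC(=O)c3cc(-c4ccncc4)n[nH]3)c2)cc1` gives 60900 nM
Compound 3 `O=C(/C=C/c1ccccc1Cl)c1cccc(NC(=O)c2cc(-c3ccncc3)n[nH]2)c1` gives 79800 nM

Compound 2 stands level with compound 1 and compound 3, all three lying within the scatter of one another. Compound 4 `CC(C)c1ccc(/C=C/C(=O)c2cccc(NC(=O)c3cc(-c4ccncc4)n[nH]3)c2)cc1`, not yet measured, has isopropyl in place of dimethylamino on an aromatic carbon, para to a large group (isopropyl in place of dimethylamino on an aromatic carbon). Going by the values given here, two measured steps bear on this change. Dimethylamino in place of chloro at that carbon gave a 1.3-fold lower number from compound 1 to compound 2 (0.11 log units; within the scatter), and 2-chlorophenyl in place of 4-(dimethylamino)phenyl gave a 1.3-fold higher number from compound 2 to compound 3 (0.12 log units; within the scatter). Neither step leaves the scatter, so none beyond it is expected here. The expected step is a 1.1-fold higher number from compound 2 to compound 4 (0.06 log units; within the scatter) in this assay, a small one. For compound 4 the estimated value is 70000 nM, with an expected range from 40000 nM to 115000 nM in this assay.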

Compound 4, half-maximal inhibitory concentration: 60200 nM
For compound 4 the middle estimate is 1.2-fold (0.07 log units) above the measured one, and the stated range covers the measured number.
By their numbers in this assay, from the lowest: compounds 4, 2, 1 and 3 (each within the scatter of the next).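

In this assay, taking out dimethylamino, with its nitrogen and its hydrogen-bond acceptor, and putting in isopropyl at this aromatic carbon leaves the number level (a 1.0-fold lower number from compound 2 to compound 4 (0.01 log units; within the scatter)). Isopropyl also stands level with chloro at that carbon (a 1.3-fold lower number from compound 1 to compound 4 (0.12 log units; within the scatter)) and with the 2-chlorophenyl variant (a 1.3-fold lower number from compound 3 to compound 4 (0.12 log units; within the scatter)), so this position has now tolerated a group with no hydrogen-bond acceptor without leaving the scatter. No measurement at hand gives a reason for this flat result. The compounds shown leave open whether a carboxylic acid or a longer chain at this carbon would move the number beyond the scatter.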